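Where the Acid Sits: Compound 1 to Compound 4

The source may report more compounds than this note shows. Statements on the series, on what has been measured and on what is new or still open speak of the compounds shown alone.

The measured compounds:
`O=C(O)c1cccc(-c2cnc(C(O)CCc3ccc(-c4ccccc4)cc3)o2)n1` compound 1, 1100 nM
`O=C(O)c1cccc(-c2cnc(CCCc3ccc(-c4ccccc4)cc3)o2)n1` compound 2, 10000 nM
`CSc1cnc(C(=O)CCc2ccc(-c3ccccc3)cc2)o1` compound 3, 3 nM

In an assay for inhibition of Fatty-acid amide hydrolase 1 (Rattus norvegicus) (a higher number here means a weaker inhibitor, a lower number a stronger inhibitor), compound 1 gives 1100 nM, the second highest of the three numbers. Compound 2 `O=C(O)c1cccc(-c2cnc(CCCc3ccc(-c4ccccc4)cc3)o2)n1` stands nearest, a 9.1-fold higher number from compound 1 to compound 2 (0.96 log units; beyond the scatter). Compound 3 `CSc1cnc(C(=O)CCc2ccc(-c3ccccc3)cc2)o1` lies furthest, with 3 nM. Compound 4 `O=C(O)c1ccc(-c2cnc(C(O)CCc3ccc(-c4ccccc4)cc3)o2)nc1` keeps every atom of compound 1 and differs only in 5-carboxypyridin-2-yl in place of 6-carboxypyridin-2-yl on an aromatic carbon. No measured step moves the carboxylic acid around its ring: the one step shown touches the chain hydroxy instead, and compound 3 carries a different substituent on the shared core altogether, so neither bears directly on this change. Compound 4 is therefore expected to stay close, a 1.8-fold higher number from compound 1 to compound 4 (0.26 log units; within the scatter), within the scatter or slightly weaker. The estimate for compound 4 is 2000 nM, between 500 nM and 8000 nM.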

Compound 4, inhibition constant: 10000 nM
Estimate against measurement, compound 4: 5.0-fold (0.70 log units) below, and the stated range ends below it.
By their numbers in this assay, from the lowest: compound 3; then compound 1; then compounds 2 and 4 (each within the scatter of the next).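

In this assay the place of the carboxylic acid on its ring matters even with every atom kept, as 5-carboxypyridin-2-yl in place of 6-carboxypyridin-2-yl gives a 9.1-fold higher number from compound 1 to compound 4 (0.96 log units; beyond the scatter). This single move on the aromatic carbon costs as much as the loss of the chain hydroxy, a 9.1-fold higher number from compound 1 to compound 2 (0.96 log units; beyond the scatter). Nothing measured here explains why the acid's place has this effect. The compounds shown leave open whether a methyl ester or a primary amide in place of the carboxylic acid would keep this dependence on its place.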